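Chloro for hydrogen at two different places in one series

This account rests on a few compounds, and the source may have more. Where it says the series, first, only, none or still open, it means among the compounds named here.

Measured so far in a functional assay on A549 cells (Homo sapiens) for antiproliferative activity, read by MTT assay, with a stated time of 48 h; on this read-out higher numbers stand for weaker inhibition and lower numbers for stronger inhibition:
compound 1 `Fc1ccc2[nH]c(-c3cn(-c4ccccc4)nc3-c3ccccc3)nc2c1` gives 1720 nM
compound 2 `Fc1ccc2[nH]c(-c3cn(-c4ccccc4)nc3-c3ccc(Cl)cc3)nc2c1` gives 4610 nM
compound 3 `COc1ccc(-c2nn(-c3ccccc3)cc2-c2nc3cc(Cl)ccc3[nH]2)cc1` gives 3130 nM

Compound 2 differs from compound 1 by chloro in place of hydrogen on an aromatic carbon. The step reads a 2.7-fold higher number from compound 1 to compound 2 (0.43 log units; beyond the scatter). Compound 3 and compound 1 differ in more than one place; the difference between the two cores is not broken down here.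

Compound 4 `COc1ccc(-c2nn(-c3ccccc3)cc2-c2nc3cc(Cl)c(Cl)cc3[nH]2)cc1` is not yet measured. It differs from compound 3 by chloro in place of hydrogen on an aromatic carbon. This is the same kind of change as that between compound 1 and compound 2, but not the same: there the chloro entered on a six-membered aromatic ring of carbon only, para to a large group; here it enters on a ring that is part of a fused or bridged system of two rings, ortho to a chloro group, meta to a fused ring and para to a fused ring.

For the measured compounds named here, the only precedent in this set is a 2.7-fold higher number from compound 1 to compound 2 (0.43 log units; beyond the scatter), a modest weakening. The expected step in this assay is therefore a 1.8-fold higher number from compound 3 to compound 4 (0.24 log units; within the scatter), kept wide since the place is different. Compound 4 is expected at 5500 nM, within 2200 nM to 14000 nM.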

Compound 4, half-maximal inhibitory concentration: 7330 nM
The estimate for compound 4 lay 1.3-fold (0.12 log units) below the measured number; low and high end bracket the measured number.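

In this assay, chloro in place of hydrogen on an aromatic carbon of the fused system of two rings, ortho to a chloro group, gives a 2.3-fold higher number from compound 3 to compound 4 (0.37 log units; beyond the scatter). Set beside the earlier step, where the chloro entered on a six-membered aromatic ring of carbon only, the change carries over between the two cores in direction and in size, although the place differs: the same change on two cores in this assay, a 2.7-fold higher number (0.43 log units; beyond the scatter) from compound 1 to compound 2 and a 2.3-fold higher number (0.37 log units; beyond the scatter) from compound 3 to compound 4, 1.1-fold (0.06 log units) apart, within the scatter of two such steps. For the compounds shown here, these are only two pairs, and core and place differ together between them, so the agreement does not separate one from the other, does not explain the weakening, and does not establish a rule for other places or other cores.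

From the compounds shown here alone, it remains open whether the weakening is particular to chloro or would also follow from a different group at these places, such as a hydroxyl group, an amine or a carboxylic acid. Going by these compounds, it also remains open whether the two steps would keep their size on other cell lines.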